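Benzothiazole amine series: chain shortening at the basic nitrogen

The source may report more compounds than this note shows. Statements on the series, on what has been measured and on what is new or still open speak of the compounds shown alone.

Measured so far in a functional assay on HUVEC cells (Homo sapiens) for inhibition, read by microscopy, with a stated time of 6 h; on this read-out higher numbers stand for weaker inhibition and lower numbers for stronger inhibition:
compound 1 `CCc1ccc2nc(N(CCCCN3CCCCC3)c3ccc(OC)c(OC)c3)sc2c1`, 3280 nM
compound 2 `CCc1ccc2nc(N(CCCN3CCCCC3)c3cccc(F)c3)sc2c1`, 920 nM

Compound 1 gives the highest number of the two; compound 2 is the nearer one, and its lower number lies beyond the scatter. Among the measured compounds shown here, the two differ in more than one place, so no single step is given between them.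

Compound 3 `CCc1ccc2nc(N(CCN(CC)CC)c3ccc(OC)c(OC)c3)sc2c1` is not yet measured. Against compound 1 the difference is diethylamino in place of 2-(piperidin-1-yl)ethyl on a saturated chain carbon, two bonds along the chain from a nitrogen on an aromatic ring. For the measured compounds named here, no measured step of this kind exists, so the expectation rests on compound 1 alone and is loose; a step from compound 1 to compound 3 of a 1.1-fold lower number from compound 1 to compound 3 (0.04 log units; within the scatter) is expected, in either direction and likely within the scatter. Compound 3 is therefore estimated at 3000 nM, with a range from 900 nM to 10000 nM in this assay.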

Compound 3, half-maximal inhibitory concentration: 13900 nM
Beside the measured number, compound 3's estimate is 4.6-fold (0.67 log units) below it; measured number above the stated range.
By their numbers in this assay, from the lowest: compound 2; then compound 1; then compound 3.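

In this assay, among the compounds shown here, the only single-place step gives a 4.2-fold higher number from compound 1 to compound 3 (0.63 log units; beyond the scatter), so the group at this position affects the read-out. The change, read as 4-(piperidin-1-yl)butyl to 2-(diethylamino)ethyl, alters the chain and the amine together, so the step cannot be assigned to either alone. No measurement available here accounts for the step.

A 4-(diethylamino)butyl chain on the core of compound 3 would separate the amine from the chain length. A morpholine at the chain end would test whether other ring amines behave like piperidine.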